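This account rests on a few compounds, and the source may have more. Where it says the series, first, only, none or still open, it means among the compounds named here.

Measured so far in a functional assay (spleen, spleen) for activation, with Mus musculus as the target; on this read-out higher numbers stand for an effect only at larger amounts of compound and lower numbers for an effect already at smaller amounts:
compound 1 `CCCCCNc1nc(N)c2nc(O)n(Cc3ccccc3)c2n1`: 0.1 uM
compound 2 `Nc1nc(N)c2nc(O)n(Cc3ccccc3)c2n1`: 10 uM
compound 3 `Nc1nc(O)nc2c1nc(O)n2Cc1ccccc1`: 0.1 uM

Compound 1 stands level with compound 3, the two together the lowest of the three numbers; compound 2 is the furthest from compound 1, a 100-fold higher number from compound 1 to compound 2 (2.00 log units; beyond the scatter). Compound 4 `CCCCSc1nc(N)c2nc(O)n(Cc3ccccc3)c2n1` carries butylsulfanyl in place of pentylamino on an aromatic carbon. Going by the values given here, no measured step exchanges one chain for another at this place. What bears on it: a 100-fold higher number from compound 1 to compound 2 (2.00 log units; beyond the scatter), a large loss when the pentyl is removed; and no change at the digits printed from compound 1 to compound 3 (within the scatter) together with a 100-fold lower number from compound 2 to compound 3 (2.00 log units; beyond the scatter), showing that either pentylamino or hydroxy is tolerated here while a bare amino is not. Compound 4 keeps a chain of similar length, so a step within the scatter is expected, a 1.5-fold higher number from compound 1 to compound 4 (0.18 log units; within the scatter). Compound 4 is estimated at 0.15 uM, range 0.03 uM to 1 uM.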

Compound 4, minimum effective concentration: 0.01 uM
The estimate for compound 4 lay 15-fold (1.18 log units) above the measured number, and the stated range ends above it.
By their numbers in this assay, from the lowest: compound 4; then compounds 1 and 3 (each within the scatter of the next); then compound 2.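

In this assay, the position does more than tolerate a chain: butylsulfanyl in place of pentylamino gives a clear gain (a 10-fold lower number from compound 1 to compound 4 (1.00 log units; beyond the scatter)). The same group also goes beyond hydroxy (a 10-fold lower number from compound 3 to compound 4 (1.00 log units; beyond the scatter)), so the level standing of compound 1 and compound 3 is not the floor for this position, and the span against the bare amino widens (a 1000-fold lower number from compound 2 to compound 4 (3.00 log units; beyond the scatter)). No evidence on the cause of these steps is available.

On these data alone, the change alters the linking atom and the chain together, so the share of each stays open. A pentylsulfanyl or butylamino group on this carbon would separate the two.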